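Amide substituent changes on a nitro-chromene carboxamide series

The source may report more compounds than this note shows. Statements on the series, on what has been measured and on what is new or still open speak of the compounds shown alone.

Measured compounds:
Compound 1, `CNC(=O)C1=CC(C)(C)Oc2ccc([N+](=O)[O-])cc21`: 61%
Compound 2, `CC1(C)C=C(C(=O)NCC2CC2)c2cc([N+](=O)[O-])ccc2O1`: 89.3%
Compound 3, `C#CCNC(=O)C1=CC(C)(C)Oc2ccc([N+](=O)[O-])cc21`: 80.2%

In a functional assay on the whole organism (muscle tissue) with Rattus norvegicus as the target (on this read-out higher numbers stand for larger maximal responses and lower numbers for smaller maximal responses), compound 1 gives 61%. Compound 2 reaches 89.3%, and compound 3 reaches 80.2%, the second highest of the three numbers; the step reaching it from compound 2 is a number 9.1 percentage points lower from compound 2 to compound 3 (within the scatter), while its step from compound 1 is a number 19.2 percentage points higher from compound 1 to compound 3 (beyond the scatter). Compound 4, `CC1(C)C=C(C(=O)NCCO)c2cc([N+](=O)[O-])ccc2O1`, differs from compound 3 in one place: hydroxymethyl in place of ethynyl on a saturated chain carbon bound to an amide-type nitrogen.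

Among the compounds with values here, three measured steps bear on this position. Both a number 28.3 percentage points higher from compound 1 to compound 2 (beyond the scatter) and a number 19.2 percentage points higher from compound 1 to compound 3 (beyond the scatter) show that adding a carbon group on the saturated chain carbon bound to the amide-type nitrogen raised the maximal response beyond the scatter, whereas a number 9.1 percentage points lower from compound 2 to compound 3 (within the scatter) shows that exchanging one such carbon group for another stayed within the scatter. Within the data shown here, no measured step involves a hydroxymethyl group or any hydrogen-bond donor at this place, so the data give no direct precedent. Since compound 4 keeps a two-heavy-atom substituent there, it is expected to stay closer to compound 3 than to compound 1, with a step of a number 6.2 percentage points lower from compound 3 to compound 4 (within the scatter) expected in this assay. Compound 4 is therefore estimated at 74%, within a range from 58% to 90%.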

Compound 4, intrinsic activity: the largest response reached, in percent of the reference agonist's: 71.8%
Compound 4: middle estimate off by 2.2 percentage points, on the high side; measured number inside the range.
By their numbers in this assay, from the lowest: compound 1; then compounds 4, 3 and 2 (each within the scatter of the next, the first and the last beyond it).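

The step of a number 8.4 percentage points lower from compound 3 to compound 4 (within the scatter) in this assay shows that hydroxymethyl, which brings a hydrogen-bond donor and acceptor where ethynyl has none, can replace ethynyl on this saturated chain carbon without leaving the scatter. The step of a number 10.8 percentage points higher from compound 1 to compound 4 (beyond the scatter) shows that the substituent need not be a pure carbon group for the maximal response to exceed that of hydrogen at this place. The step of a number 17.5 percentage points lower from compound 2 to compound 4 (beyond the scatter) separates hydroxymethyl from cyclopropyl, a pair of groups that differ beyond the scatter where ethynyl and cyclopropyl did not.

No supporting measurement is available to explain these steps. Going by these compounds, it remains open whether an amine or a carboxylic acid in place of the hydroxyl, or a longer chain carrying the hydroxyl, would keep the response at this level.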